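Substituent swaps on the shared core: compound 4

A few compounds are considered here, and "the series" means these few. Any claim that something is new, unique, unknown or untested is made for them only; others in the source may bear on it.

Of the compounds shown here, three on the shared core have been measured. Compound 1 `CCOC(=O)N1CCC(=NNC(=O)c2ccc(Cl)cc2)CC1` gives 63900 nM in a functional assay, read by spectrophotometry; a higher number here means a weaker inhibitor, a lower number a stronger inhibitor. Compound 2 `CCOC(=O)N1CCC(=NNC(=O)c2ccc(F)cc2)CC1` gives 39200 nM in this assay. Compound 3 `CCOC(=O)N1CCC(=NNC(=O)c2ccc(C(F)(F)F)cc2)CC1` gives 23500 nM in this assay. Compound 3 holds the lowest of the three numbers, yet only its gap to compound 1 is beyond the scatter: a 2.7-fold lower number from compound 1 to compound 3 (0.43 log units; beyond the scatter). The other two steps lie within it: a 1.6-fold lower number from compound 1 to compound 2 (0.21 log units; within the scatter) and a 1.7-fold lower number from compound 2 to compound 3 (0.22 log units; within the scatter).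

Compound 4 `CCOC(=O)N1CCC(=NNC(=O)c2ccc([N+](=O)[O-])cc2)CC1` is not yet measured. It differs from compound 3 in one place: nitro in place of trifluoromethyl on an aromatic carbon. For the measured compounds named here, no measured step involves a nitro group, so the only bearing comes from the three swaps among chloro, fluoro and trifluoromethyl at the same aromatic carbon, which moved this assay by at most a modest amount, as in a 2.7-fold lower number from compound 1 to compound 3 (0.43 log units; beyond the scatter), and otherwise stayed within the scatter. On that basis the step for compound 4 is expected to be small, probably within the scatter, with no clear direction, namely a 1.1-fold higher number from compound 3 to compound 4 (0.03 log units; within the scatter). Compound 4 is therefore estimated at 25000 nM in this assay, with a range from 10000 nM to 65000 nM.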

Compound 4, half-maximal inhibitory concentration: 10900 nM
Compound 4: middle estimate off by 2.3-fold (0.36 log units), on the high side; low and high end bracket the measured number.
By their numbers in this assay, from the lowest: compound 4; then compounds 3, 2 and 1 (each within the scatter of the next, the first and the last beyond it).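

Nitro at this aromatic carbon, para to a large group, gives the first clear separation from every other compound in the series, and in this assay compound 4 is the strongest inhibitor of the four: the steps are (a 2.2-fold lower number from compound 3 to compound 4 (0.33 log units; beyond the scatter)), (a 3.6-fold lower number from compound 2 to compound 4 (0.56 log units; beyond the scatter)) and (a 5.9-fold lower number from compound 1 to compound 4 (0.77 log units; beyond the scatter)), each beyond the scatter and each still modest. Among chloro, fluoro and trifluoromethyl only one step cleared the scatter, so this position now shows a wider response to substitution than those three compounds could show, and trifluoromethyl no longer marks the low end of the series. Nitro enters with hydrogen-bond acceptors where trifluoromethyl has none, but that count is only a description of the swap, and no measurement in hand accounts for the lower number.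

Still open, on these data alone, is how an amine, a carboxylic acid or a nitrile at the same aromatic carbon would compare with nitro. Also open, as far as these compounds go, is whether the lower number with nitro carries over when another part of the shared core changes.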